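The source may hold more compounds than are shown below. What is called first, only, known or untested is meant among the compounds shown, and "the series" means these compounds.

Of the compounds shown here, three built on a shared core have been measured in an in vitro functional assay on CHO/Galpha16 cells for antagonist activity at C-C chemokine receptor type 8 (Homo sapiens), read by FLIPR; a higher number here means a weaker inhibitor, a lower number a stronger inhibitor. Compound 1 `CCCC(=O)N1CCC(NS(=O)(=O)c2ccc(NC(=O)CC3CCCC3)c3ccccc23)CC1` gives 145 nM in this assay, the second highest of the three numbers. Compound 2 `CCCC(=O)N1CCC(NS(=O)(=O)c2ccc(NC(=O)c3ccc(F)cc3)c3ccccc23)CC1` gives 59.5 nM, and compound 3 `CCCC(=O)N1CCC(NS(=O)(=O)c2ccc(NC(=O)c3ccoc3)c3ccccc23)CC1` gives 1520 nM. Compound 4 `CCCC(=O)N1CCC(NS(=O)(=O)c2ccc(NC(=O)c3cc(C)nc(Cl)c3)c3ccccc23)CC1` has not yet been measured; it differs from compound 1 in one place: 2-chloro-6-methylpyridin-4-yl in place of cyclopentylmethyl on a carbonyl carbon. Among the measured compounds shown here, two measured steps bear on this change, both swapping the cyclopentylmethyl group for an aromatic ring on the same carbonyl carbon. Toward a six-membered aromatic ring the number fell, a 2.4-fold lower number from compound 1 to compound 2 (0.39 log units; beyond the scatter); toward a five-membered aromatic ring it rose sharply, a 10-fold higher number from compound 1 to compound 3 (1.02 log units; beyond the scatter). For the measured compounds named here, the group entering in compound 4 is a six-membered aromatic ring, resembling the change that gave compound 2 rather than the one that gave compound 3, so a modest downward step or a number close to that of compound 1 is expected, with the hetero atom and chlorine leaving room for doubt. For compound 4 the estimate in this assay is 90 nM, with a range from 30 nM to 300 nM. That estimate means an expected step of a 1.6-fold lower number from compound 1 to compound 4 (0.21 log units; within the scatter).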

Compound 4, half-maximal inhibitory concentration: 43.9 nM
Beside the measured number, compound 4's estimate is 2.1-fold (0.31 log units) above it, and the stated range covers the measured number.
By their numbers in this assay, from the lowest: compounds 4 and 2 (each within the scatter of the next); then compound 1; then compound 3.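

At this place on the carbonyl carbon, a six-membered aromatic ring holding one ring nitrogen, a chlorine and a methyl is tolerated: in this assay the swap for cyclopentylmethyl gives a 3.3-fold lower number from compound 1 to compound 4 (0.52 log units; beyond the scatter), and the swap for furan-3-yl gives a 35-fold lower number from compound 3 to compound 4 (1.54 log units; beyond the scatter). Against 4-fluorophenyl, the change gives a 1.4-fold lower number from compound 2 to compound 4 (0.13 log units; within the scatter), so the two six-membered aromatic rings cannot be separated here, and the hetero atom carried no visible penalty. No measured evidence explains why these rings differ from furan-3-yl.

The compounds shown leave open what the ring nitrogen, the chlorine and the methyl each contribute, since all three enter together. Also open, as far as these compounds go, is how this ring would respond to a simple amine or a carboxylic acid in place of the chlorine.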